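The source may report more compounds than this note shows. Statements on the series, on what has been measured and on what is new or still open speak of the compounds shown alone.

The series rests on a shared core carrying a cyclopropylmethyl group, varied at one aromatic carbon. Compound 1 `COc1cc(Br)c2nnn(CC3CC3)c2c1` bears a methoxy group and a bromine; in an ADME assay on microsomes from liver (Homo sapiens) for metabolic stability, tested at 2.5 uM (on this read-out higher numbers stand for fast clearance and lower numbers for slow clearance), the entry for compound 1 reads "not determined" (no result reported). Compound 2 `Clc1cccc2c1nnn2CC1CC1` carries a chlorine, and in this assay compound 2 gives 4.2 mL/min/g. Among the measured compounds shown here, compound 3 `Fc1cccc2c1nnn2CC1CC1` carries a fluorine at the same position, and for compound 3 this assay holds no single number, its entry being recorded as "not determined" (no result reported); so compound 3 stands without a measured value, and the only number in the set is that of compound 2.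

Compound 4 `COc1cccc2c1nnn2CC1CC1` differs from compound 3 by methoxy in place of fluoro on an aromatic carbon. For the measured compounds named here, with no measured pair to anchor the step, the change from compound 3 to compound 4 in this assay is expected to be modest, with clearance in the same general region as that seen for compound 2, perhaps somewhat faster. Compound 4 is therefore estimated at 6 mL/min/g, within a range from 2 mL/min/g to 15 mL/min/g.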

Compound 4, intrinsic clearance in a liver preparation (reported as CLH), per the amount of preparation that the assay uses: 1.8 mL/min/g
Estimate against measurement, compound 4: 3.3-fold (0.52 log units) above; measured number below the stated range.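

In this assay, among the compounds shown here, the first comparison at this aromatic carbon comes with methoxy in place of chloro, which gives a 2.3-fold lower number from compound 2 to compound 4 (0.37 log units; beyond the scatter), a step beyond the usual scatter, so the read-out does respond to the group held at this position. For the compounds shown here, the step from fluoro to methoxy cannot be read, since compound 3 holds no number, and so the single step rests on the chloro and methoxy pair alone. Nothing given here offers a measured reason for the direction of this step.

The compounds shown leave open how an amine or a longer alkoxy chain on this same aromatic carbon would read in this assay. They also leave open whether the step would hold with something other than the cyclopropylmethyl group on the shared core.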